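From 2-chlorophenyl to 4-chlorophenyl in the series

The source may hold more compounds than are shown below. What is called first, only, known or untested is meant among the compounds shown, and "the series" means these compounds.

In a functional assay on NCI-H460 cells (Homo sapiens) for cytotoxicity, read by sulforhodamine B assay (on this read-out higher numbers stand for weaker inhibition of growth and lower numbers for stronger inhibition of growth), compound 1 (`CC1=CC[C@@H]([C@@](C)(O)CCCC(C)(C)NC(=S)NN)CC1`) gives 12800 nM, compound 2 (`CC1=CC[C@@H]([C@@](C)(O)CCCC(C)(C)NC(=S)N/N=C\c2cccc([N+](=O)[O-])c2)CC1`) gives 8290 nM and compound 3 (`CC1=CC[C@@H]([C@@](C)(O)CCCC(C)(C)NC(=S)N/N=C\c2ccccc2Cl)CC1`) gives 24600 nM. Compound 3 cannot be separated from the unsubstituted core of compound 1, with a 1.9-fold higher number from compound 1 to compound 3 (0.28 log units; within the scatter). It does stand apart from compound 2, with a 3.0-fold higher number from compound 2 to compound 3 (0.47 log units; beyond the scatter), a modest step and the only one in the set beyond the scatter.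

Compound 4 (`CC1=CC[C@@H]([C@@](C)(O)CCCC(C)(C)NC(=S)N/N=C\c2ccc(Cl)cc2)CC1`) has not yet been measured in this assay. Its change from compound 3 is 4-chlorophenyl in place of 2-chlorophenyl on a carbon with a double bond to nitrogen. For the measured compounds named here, no measured pair moves a single group around the aromatic ring, so the evidence is indirect. The swap at this same carbon in compound 2 and compound 3 gave a 3.0-fold higher number from compound 2 to compound 3 (0.47 log units; beyond the scatter), which suggests that a modest step is about the most to expect here. With compound 3 and compound 1 this close, no step beyond the scatter is expected, with only a slight lean towards a lower number. The expected change is a 1.5-fold lower number from compound 3 to compound 4 (0.19 log units; within the scatter). For compound 4 the estimated value is 16000 nM, with an expected range of 7000 nM to 36000 nM.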

Compound 4, concentration for 50% growth inhibition: 8720 nM
Estimate against measurement, compound 4: 1.8-fold (0.26 log units) above, within the range that was stated.
By their numbers in this assay, from the lowest: compounds 2, 4, 1 and 3 (each within the scatter of the next, the first and the last beyond it).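

Notes on the chlorine position: in this assay, the same atoms joined differently give a modest step beyond the scatter (a 2.8-fold lower number from compound 3 to compound 4 (0.45 log units; beyond the scatter)), so at this carbon with a double bond to nitrogen the reading depends on where the chlorine stands on the ring and not only on which atoms are present. For the compounds shown here, the 4-chlorophenyl group cannot be separated from the 3-nitrophenyl group (a 1.1-fold higher number from compound 2 to compound 4 (0.02 log units; within the scatter)) or from the core of compound 1 (a 1.5-fold lower number from compound 1 to compound 4 (0.17 log units; within the scatter)), which leaves the 2-chlorophenyl group of compound 3 as the one apart from compound 2 and compound 4, though compound 3 itself remains within the scatter of compound 1. No measurement shown bears on the reason for the step between the two chlorophenyl groups.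

Open, as far as these compounds go, is whether a plain phenyl group, or a phenyl ring carrying fluorine, bromine or methoxy in place of the chlorine, would read with the 2-chlorophenyl group or with the 4-chlorophenyl group. Also open, from the compounds shown here alone, is whether any aromatic group at this carbon can move the number beyond the scatter from compound 1.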